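The source may report more compounds than this note shows. Statements on the series, on what has been measured and on what is new or still open speak of the compounds shown alone.

Series notes. In a functional assay on HCT-116 cells (Homo sapiens), read by MTT assay, with a stated time of 72 h (a lower number here means a stronger inhibitor, a higher number a weaker inhibitor), compound 2 `CNc1ncnc2c1c(-c1ccco1)cn2[C@@H]1O[C@H](CO)[C@@H](O)[C@H]1O` gives 230 nM, the only numerical result in hand. Compound 1 `COc1nc(N)nc2c1c(-c1ccco1)cn2[C@@H]1O[C@H](CO)[C@@H](O)[C@H]1O` reaches only the assay limit in this assay, > 20000 nM, as recorded in the limit of > 20000 nM in this assay, at which 1 of the 2 values shown sits. Compound 3 `COc1ncnc2c1c(-c1ccco1)cn2[C@@H]1O[C@H](CO)[C@@H](O)[C@H]1O` has not yet been run. The change from compound 2 to compound 3 is methoxy in place of methylamino on an aromatic carbon. For the measured compounds named here, with no measured step of this kind available, the expectation for the step from compound 2 to compound 3 in this assay is a loss of potency beyond the scatter, a 13-fold higher number from compound 2 to compound 3 (1.12 log units; beyond the scatter). Compound 3 is accordingly estimated at 3000 nM, within the range 500 nM to 20000 nM.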

Compound 3, half-maximal inhibitory concentration: 40 nM
Beside the measured number, compound 3's estimate is 75-fold (1.88 log units) above it, and the stated range ends above it.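

In this assay, methoxy in place of methylamino on this aromatic carbon gives a 5.8-fold lower number from compound 2 to compound 3 (0.76 log units; beyond the scatter), so potency here does not depend on keeping methylamino. With methoxy kept, hydrogen in place of amino gives an at least 500-fold lower number from compound 1 to compound 3 (2.69 log units; beyond the scatter), which makes the amino group of compound 1 the larger liability in this pair. That step is only a bound, as compound 1 stands at an assay limit: the limit of > 20000 nM in this assay, at which 1 of the 3 values shown sits.

On these data alone, whether ethoxy, dimethylamino or chlorine on this carbon would keep the gain remains open. Also open, as far as these compounds go, is whether the amino penalty persists with methylamino in place of methoxy.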